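The source may report more compounds than this note shows. Statements on the series, on what has been measured and on what is new or still open speak of the compounds shown alone.

Among the compounds with values here, compound 1 `O=C(O)c1ccccc1-c1ccc(CCc2ncc(CC3CCC3)[nH]2)cc1` in an in vitro functional assay on cells for agonist activity at Bombesin receptor subtype-3 (Mus musculus), read by luminescence and calcium flux (a lower number here means that less compound is needed, a higher number that more compound is needed for the effect), gives 7.1 nM, the highest of the two numbers measured so far; its nearest neighbour is compound 2 `CC(C)(C)Cc1cnc(CCc2ccc(-c3ccccc3C(=O)O)cc2)[nH]1`, which in this assay gives 6.3 nM, and the step of a 1.1-fold lower number from compound 1 to compound 2 (0.05 log units; within the scatter) lies within the scatter. Compound 3 `COc1cccc(Cc2cnc(CCc3ccc(-c4ccccc4C(=O)O)cc3)[nH]2)c1` is not yet measured. Its difference from compound 1 is 3-methoxyphenyl in place of cyclobutyl on a saturated chain carbon bound to an aromatic carbon. Within the data shown here, the only measured step at this position, a 1.1-fold lower number from compound 1 to compound 2 (0.05 log units; within the scatter), exchanged one group of carbon only for another of similar size and changed nothing beyond the scatter; no measured compound carries a six-membered aromatic ring with a hydrogen-bond acceptor there, so that step bears on the present change only loosely. The expected step of a 2.1-fold higher number from compound 1 to compound 3 (0.32 log units; beyond the scatter) is therefore modest and of uncertain direction. For compound 3 in this assay the estimate is 15 nM, within a range from 3 nM to 70 nM.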

Compound 3, half-maximal effective concentration: 79 nM
Compound 3: middle estimate off by 5.3-fold (0.72 log units), on the low side; the measured number lies above the stated range.
By their numbers in this assay, from the lowest: compounds 2 and 1 (each within the scatter of the next); then compound 3.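

In this assay, the position on a saturated chain carbon bound to an aromatic carbon turns out not to be indifferent to its group: the change to 3-methoxyphenyl gives an 11-fold higher number from compound 1 to compound 3 (1.05 log units; beyond the scatter) and also a 13-fold higher number from compound 2 to compound 3 (1.10 log units; beyond the scatter). Within the data shown here, the earlier exchange between cyclobutyl and tert-butyl, both of carbon only, gave no hint of a step of this size, so a tolerance for swapping one of these groups for the other does not extend to 3-methoxyphenyl. The data at hand offer no explanation for the size of these steps.

The compounds shown leave open whether the higher number goes with the aromatic ring or with the methoxy group, a question that unsubstituted phenyl or cyclohexyl at this place could separate. Also open, from the compounds shown here alone, is how 4-methoxyphenyl or a group carrying an amine would read here.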